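Trifluoromethyl for Trifluoromethoxy on Two Related Anilide Cores

The compounds below may be only part of what the source reports. "The series", "measured", "known", "first", "only" and "open" are said of these compounds alone.

Three compounds were measured in a functional assay on Jurkat cells (Homo sapiens) for cytotoxicity, read by luminescence and CellTiter-Glo, with a stated time of 3 days; a higher number here means a weaker inhibitor, a lower number a stronger inhibitor:

compound 1, `O=C(Nc1cccc(C(F)(F)F)c1)c1cc(F)ccc1O`, 840 nM
compound 2, `O=C(Nc1ccc(OC(F)(F)F)c(Cl)c1)c1cc(Cl)ccc1O`, 840 nM
compound 3, `O=C(Nc1cccc(OC(F)(F)F)c1)c1cc(F)ccc1O`, 700 nM

Compound 3 and compound 1 share a core and differ in one place: trifluoromethyl in place of trifluoromethoxy on an aromatic carbon. That change produced a 1.2-fold higher number from compound 3 to compound 1 (0.08 log units; within the scatter), so the two numbers sit together within the usual scatter and no order between them can be claimed.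

Compound 2 stands level with compound 1 at the digits shown and within the scatter of compound 3. Its core differs from the core of compound 3 in more than one place, and that difference is not broken down here.

Compound 4, `O=C(Nc1ccc(C(F)(F)F)c(Cl)c1)c1cc(Cl)ccc1O`, has not yet been measured. It differs from compound 2 by trifluoromethyl in place of trifluoromethoxy on an aromatic carbon. For the measured compounds named here, this is the same kind of change as the one from compound 3 to compound 1, but not the same: there the place was meta to a large group, here it is ortho to a chloro group and para to a large group.

Going by the values given here, nothing among the measured compounds separates the two cores in their response to this change, so the expectation rests on the one measured step. The expected step is a 1.1-fold higher number from compound 2 to compound 4 (0.05 log units; within the scatter), because a 1.2-fold higher number from compound 3 to compound 1 (0.08 log units; within the scatter) lay within the scatter. Compound 4 is therefore estimated to give 950 nM, with a range from 450 nM to 2000 nM.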

Compound 4, half-maximal inhibitory concentration: 690 nM
For compound 4 the middle estimate is 1.4-fold (0.14 log units) above the measured one, within the range that was stated.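

In this assay, trifluoromethyl in place of trifluoromethoxy on the core of compound 2 gave a 1.2-fold lower number from compound 2 to compound 4 (0.09 log units; within the scatter) and so left that pair together, with no order between them to claim. Set beside the same exchange on the other core, this step does not differ from the earlier one: the same change on two cores in this assay, a 1.2-fold higher number (0.08 log units; within the scatter) from compound 3 to compound 1 and a 1.2-fold lower number (0.09 log units; within the scatter) from compound 2 to compound 4, 1.5-fold (0.16 log units) apart, within the scatter of two such steps. The two pairs therefore show that, on these two cores, the exchange can be carried from one to the other without a difference that can be read, and that neither core moved beyond the scatter; they do not show a direction for the change, nor do they show that it would stay this quiet on any other core or at any other place on the ring.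

The compounds shown hold only trifluoromethyl and trifluoromethoxy at this place, so it remains open whether an amine, a carboxylic acid, a nitrile or a longer chain there would move the number beyond the scatter. It also remains open which of the several differences between the two cores matters on its own, as no pair shown isolates any one of them.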